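The source may hold more compounds than are shown below. What is called first, only, known or untested is meant among the compounds shown, and "the series" means these compounds.

The measured compounds in a functional assay on HeLa cells (Homo sapiens) for cytotoxicity, read by MTT assay; on this read-out lower numbers stand for stronger inhibition and higher numbers for weaker inhibition:
Compound 1 `CC(C)=CC[C@@H](OC(=O)c1ccoc1)C1=CC(=O)c2c(O)ccc(O)c2C1=O` gives > 100000 nM, which is a limit of the assay rather than a number.
Compound 2 `CC(C)=CC[C@@H](OC[C@H](C)O)C1=CC(=O)c2c(O)ccc(O)c2C1=O` gives 40300 nM.
Compound 3 `CC(C)=CC[C@@H](OC(=O)C1CCCCO1)C1=CC(=O)c2c(O)ccc(O)c2C1=O` gives > 100000 nM, again a limit rather than a number.

Compound 3 therefore sits at the limit shared by two of the three values, (the limit of > 100000 nM in this assay, at which 2 of the 3 values shown sit). Of the steps leading to it, one is a step that the two limits leave unreadable from compound 1 to compound 3, and the other is an at least 2.4-fold higher number from compound 2 to compound 3 (0.39 log units; beyond the scatter). Within the data shown here, the only compound with a measured number, compound 2, carries a 2-hydroxypropyl group on the oxygen on the saturated carbon.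

Compound 4 `CCCC(C)(O)CC(=O)O[C@H](CC=C(C)C)C1=CC(=O)c2c(O)ccc(O)c2C1=O` differs from compound 3 in one place: 2-hydroxy-2-methylpentyl in place of oxan-2-yl on a carbonyl carbon. Like compound 2, compound 4 carries a hydrogen-bond donor in the side group. The step from compound 2 to compound 3 bears most directly on this change; it was at least modest and ran toward the limit. Bringing a donor back is expected to move the number at most slightly inside the limit, so the estimated step is an at least 1.2-fold lower number from compound 3 to compound 4 (0.09 log units; that floor lies within the scatter). Compound 4 is estimated at 80000 nM, within 30000 nM to 200000 nM, with a real chance that the assay reports only a limit again.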

Compound 4, half-maximal inhibitory concentration: 72000 nM
Compound 4: middle estimate off by 1.1-fold (0.05 log units), on the high side, and the stated range covers the measured number.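

In this assay, among these compounds, compound 4 is the only compound with a carbonyl on this oxygen that gives a number rather than a limit, and the steps to it are an at least 1.3-fold lower number from compound 3 to compound 4 (0.14 log units; that floor lies within the scatter) and an at least 1.3-fold lower number from compound 1 to compound 4 (0.14 log units; that floor lies within the scatter). Both steps are only floors: the limit of > 100000 nM in this assay, at which 2 of the 4 values shown sit. Set against the 2-hydroxypropyl group, the result is a 1.8-fold higher number from compound 2 to compound 4 (0.25 log units; within the scatter), so among these four compounds the two side groups holding a hydrogen-bond donor give numbers that cannot be told apart, while the two without one stay at the limit.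

On these data alone, it remains open whether the hydroxyl group itself carries this difference, as 2-hydroxy-2-methylpentyl also has no ring, unlike oxan-2-yl. As far as these compounds go, how a plain 2-methylpentyl chain, or an amine in place of the hydroxyl, would read also stays open.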